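Notes on removing the ring methyl: compound 3 to compound 4

The compounds below may be only part of what the source reports. "The series", "measured", "known", "first", "only" and "open" are said of these compounds alone.

Measured in an assay on cells for inhibition of sodium/hydrogen exchanger (Oryctolagus cuniculus); on this read-out higher numbers stand for weaker inhibition and lower numbers for stronger inhibition:
- compound 1 `CCC1CS(=O)(=O)c2cc(C(=O)N=C(N)N)c(C)cc21` gives 24 nM
- compound 2 `Cc1cc2c(cc1C(=O)N=C(N)N)S(=O)(=O)CC2C` gives 44 nM
- compound 3 `Cc1cc2c(cc1C(=O)N=C(N)N)S(=O)(=O)C(C)C2N` gives 56 nM

Compound 3 stands apart from compound 1 by a step beyond the scatter, with the higher number on the side of compound 3; against compound 2 the two numbers lie within the scatter of each other, so no order between them is claimed.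

Compound 4 `Cc1cc2c(cc1C(=O)N=C(N)N)S(=O)(=O)CC2N` is not yet measured. It differs from compound 3 by hydrogen in place of methyl on a saturated ring carbon, the carbon in question sitting next to the ring sulfur and next to the ring atom that bears an amino group.

Going by the values given here, the only measured step of the same kind is a 1.8-fold higher number from compound 1 to compound 2 (0.26 log units; within the scatter), where a methyl left a chain carbon rather than a ring carbon. That step was small and stayed within the scatter, so the loss of one carbon at the present place is expected to move this assay little, if at all, with the direction most likely toward a somewhat higher number, as in a 1.8-fold higher number from compound 1 to compound 2 (0.26 log units; within the scatter).

For compound 4 the expected step is a 1.2-fold higher number from compound 3 to compound 4 (0.06 log units; within the scatter), and the estimate in this assay is 65 nM, with a range from 30 nM to 140 nM.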

Compound 4, half-maximal inhibitory concentration: 116 nM
Estimate against measurement, compound 4: 1.8-fold (0.25 log units) below; the measured number falls inside the stated range.
By their numbers in this assay, from the lowest: compounds 1, 2 and 3 (each within the scatter of the next, the first and the last beyond it); then compound 4.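

In this assay, going by these compounds alone, the methyl on the saturated ring carbon next to the ring sulfur makes a readable difference: hydrogen in its place gives a 2.1-fold higher number from compound 3 to compound 4 (0.32 log units; beyond the scatter), whereas the only earlier step of this kind, on a chain carbon, was a 1.8-fold higher number from compound 1 to compound 2 (0.26 log units; within the scatter). Compound 4 also sets the amino group against the alkyl groups on the saturated ring carbon, with amino in place of methyl giving a 2.6-fold higher number from compound 2 to compound 4 (0.42 log units; beyond the scatter) and amino in place of ethyl giving a 4.8-fold higher number from compound 1 to compound 4 (0.68 log units; beyond the scatter), which leaves compound 4 as the weakest inhibitor of the four. No measurement at hand accounts for the loss on removing the methyl.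

These compounds leave open whether a larger group on the carbon next to the ring sulfur, such as an ethyl or a hydroxyl, would keep or improve on the number of compound 3. They also leave open whether the methyl at this place has a similar effect when the neighbouring ring atom bears a methylamino or a hydroxyl group instead of the amino group.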